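Another methoxy group on compound 2

This account rests on a few compounds, and the source may have more. Where it says the series, first, only, none or still open, it means among the compounds named here.

Among the compounds with values here, in a functional assay on HCT-15 cells (Homo sapiens) for cytotoxicity, read by colorimetric assay and MTT assay (a higher number here means a weaker inhibitor, a lower number a stronger inhibitor), compound 1 `COc1cccc2cc(-c3ccccc3)c(O)nc12` gives 10000 nM and compound 2 `COc1ccc(-c2cc3cccc(OC)c3nc2O)cc1` gives 10000 nM, so compound 2 stands level with its only measured neighbour. Compound 3 `COc1ccc(-c2cc3c(OC)ccc(OC)c3nc2O)cc1` differs from compound 2 by one change, methoxy in place of hydrogen on an aromatic carbon: a methoxy in place of hydrogen on an aromatic carbon, para to a methoxy group. Within the data shown here, the one measured step of this kind, no change at the digits printed from compound 1 to compound 2 (within the scatter), placed its methoxy elsewhere, so it is only a loose guide. On that single precedent, the expected step is no change at the digits printed from compound 2 to compound 3 (within the scatter), none beyond the scatter. Compound 3 is estimated at 10000 nM, with an expected range of 3000 nM to 15000 nM.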

Compound 3, half-maximal inhibitory concentration: 10000 nM
For compound 3 middle estimate and measured number coincide at the digits printed; measured number inside the range.
By their numbers in this assay, from the lowest: compounds 1, 2 and 3 (each within the scatter of the next).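

In this assay, adding a methoxy on the carbon-only aromatic ring, para to a methoxy group, gives no change at the digits printed from compound 2 to compound 3 (within the scatter) and leaves the reading level. The earlier step of no change at the digits printed from compound 1 to compound 2 (within the scatter) put its methoxy elsewhere, so two different placements of this group now show no change beyond the scatter. Nothing measured here offers an explanation for this flat result.

From the compounds shown here alone, whether an amine or a carboxylic acid at this position would shift the reading remains open. So does whether a longer chain such as ethoxy would behave like methoxy.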